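Benzyl in Place of Isopropyl on the Carbamoyl Nitrogen

A few compounds are considered here, and "the series" means these few. Any claim that something is new, unique, unknown or untested is made for them only; others in the source may bear on it.

Measured so far:
Compound 1 `NCCC(=O)Nc1nc2ccc(NC(=O)c3c(Cl)cccc3Cl)cc2s1` gives 5.3 ug/mL in a functional assay on WI-38 VA13 cells (Homo sapiens) for cytotoxicity; a higher number here means that more compound is needed for the effect, a lower number that less compound is needed.
Compound 2 `CC(C)NC(=O)Nc1nc2ccc(NC(=O)c3c(Cl)cccc3Cl)cc2s1` gives 0.03 ug/mL in this assay.

Compound 2 stands lowest of the two numbers. For the measured compounds named here, the single step known so far, a 180-fold lower number from compound 1 to compound 2 (2.25 log units; beyond the scatter), separates it from its only neighbour and came from isopropylamino in place of 2-aminoethyl on a carbonyl carbon. Compound 3 `O=C(NCc1ccccc1)Nc1nc2ccc(NC(=O)c3c(Cl)cccc3Cl)cc2s1` has not yet been measured. It differs from compound 2 by benzyl in place of isopropyl on an amide-type nitrogen. That one step, a 180-fold lower number from compound 1 to compound 2 (2.25 log units; beyond the scatter), touches the same side of the molecule but alters a different part of it, so it bears only loosely on the present change; what it does show is that this part of compound 2 can move the number a long way. The step from compound 2 to compound 3 is therefore expected to be modest and of uncertain direction, a 1.7-fold higher number from compound 2 to compound 3 (0.22 log units; within the scatter). Compound 3 is estimated at 0.05 ug/mL, within 0.01 ug/mL to 0.3 ug/mL.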

Compound 3, half-maximal effective concentration: 0.15 ug/mL
Compound 3: middle estimate off by 3.0-fold (0.48 log units), on the low side, within the range that was stated.
By their numbers in this assay, from the lowest: compound 2; then compound 3; then compound 1.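

On the amide-type nitrogen, the two carbon-only groups are distinguishable in this assay: exchanging isopropyl for benzyl gives a 5.0-fold higher number from compound 2 to compound 3 (0.70 log units; beyond the scatter) and so goes beyond the scatter, with compound 2 keeping the lower number. Benzylamino also retains much of the difference from the 2-aminoethyl group, with a 35-fold lower number from compound 1 to compound 3 (1.55 log units; beyond the scatter) still counted as a large step, so the low numbers of this small set are not confined to isopropylamino. Nothing available explains why benzyl and isopropyl differ here.

The compounds shown leave open whether a methyl group, a cyclohexylmethyl group or a longer chain such as phenethyl would fall nearer compound 2 or compound 3. They also leave open how a chlorine or an amine on the benzyl ring would shift the number.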